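Swapping trifluoromethoxy for fluoro on the aroyl ring

A few compounds are considered here, and "the series" means these few. Any claim that something is new, unique, unknown or untested is made for them only; others in the source may bear on it.

Of the compounds shown here, three sharing one core have been measured in an assay on cells for displacement of a labelled ligand from prostaglandin D2 receptor 2 (Homo sapiens), read by scintillation counting, with a stated time of 60 min; a lower number here means a stronger inhibitor, a higher number a weaker inhibitor. Compound 1 `O=C(O)CCC(=O)N(C1CC1)C1c2ccccc2N(C(=O)OCc2ccccc2)C2CCC21` gives 25 nM, compound 2 `O=C(O)CCC(=O)N(C1CC1)[C@H]1c2ccccc2N(C(=O)c2cccc(OC(F)(F)F)c2)[C@H]2CC[C@H]21` gives 5 nM, and compound 3 `O=C(O)CCC(=O)N(C1CC1)[C@H]1c2ccccc2N(C(=O)c2ccc(OC(F)(F)F)cc2)[C@H]2CC[C@H]21` gives 4 nM. Compound 3 has the lowest number of the three; compound 2 lies within the scatter of it, while compound 1 sits beyond the scatter at a higher number. Among the measured compounds shown here, the only single-place step in this set is a 1.3-fold lower number from compound 2 to compound 3 (0.10 log units; within the scatter), which merely moves the trifluoromethoxy group on the ring attached to the carbonyl carbon and changes nothing beyond the scatter.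

Compound 4 `O=C(O)CCC(=O)N(C1CC1)[C@H]1c2ccccc2N(C(=O)c2ccc(F)cc2)[C@H]2CC[C@H]21` differs from compound 3 by fluoro in place of trifluoromethoxy on an aromatic carbon. For the measured compounds named here, no measured step tests the loss of a trifluoromethoxy group, so the data give no direct guide. Since both trifluoromethoxy compounds sit at the low end, compound 4 is expected to move to a somewhat higher number, a 2.5-fold higher number from compound 3 to compound 4 (0.40 log units; beyond the scatter), though possibly not beyond the scatter. Compound 4 is therefore estimated at 10 nM in this assay, within a range of 4 nM to 30 nM.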

Compound 4, inhibition constant: 7.3 nM
Compound 4: middle estimate off by 1.4-fold (0.14 log units), on the high side, and the stated range covers the measured number.
By their numbers in this assay, from the lowest: compounds 3, 2 and 4 (each within the scatter of the next); then compound 1.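

In this assay the change from trifluoromethoxy to fluoro on an aromatic carbon, para to a large group, stays within the scatter (a 1.8-fold higher number from compound 3 to compound 4 (0.26 log units; within the scatter)), so the five heavy atoms of trifluoromethoxy can give way to a single fluorine without a change that these data can resolve. The comparison with the other trifluoromethoxy compound reads the same way (a 1.5-fold higher number from compound 2 to compound 4 (0.16 log units; within the scatter)), which shows that at this level of scatter the three aroyl compounds cannot be separated from one another. Nothing in the data shown bears on the reason for this result.

The compounds shown leave open how a phenyl ring with no group at this place would read, and how an amine or a carboxylic acid would read there.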